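The source may hold more compounds than are shown below. What is called first, only, known or untested is meant among the compounds shown, and "the series" means these compounds.

Compound 1 `COc1ccc(N2CCN(C(=S)SCc3ccc4nc(N)nc(N)c4c3)CC2)cc1` gives 1590 nM in a functional assay on A549 cells (Homo sapiens) for antiproliferative activity, read by MTT assay, with a stated time of 72 h (on this read-out higher numbers stand for weaker inhibition and lower numbers for stronger inhibition), the lowest of the three numbers shown. Compound 3 `Nc1nc(N)c2cc(CSC(=S)N3CCN(c4ccc([N+](=O)[O-])cc4)CC3)ccc2n1` gives 1910 nM, and compound 2 `Cc1ccccc1N1CCN(C(=S)SCc2ccc3nc(N)nc(N)c3c2)CC1` gives 3920 nM. Compound 4 `Nc1nc(N)c2cc(CSC(=S)N3CCN(c4ccccn4)CC3)ccc2n1` carries pyridin-2-yl in place of 4-methoxyphenyl on an amine nitrogen in a ring. Going by the values given here, three steps bear on this change to the group on the ring nitrogen. Exchanging 4-methoxyphenyl for 2-methylphenyl gave a 2.5-fold higher number from compound 1 to compound 2 (0.39 log units; beyond the scatter), whereas a 2.1-fold lower number from compound 2 to compound 3 (0.31 log units; beyond the scatter) moved the number back, and a 1.2-fold higher number from compound 1 to compound 3 (0.08 log units; within the scatter) stayed within the scatter. Swapping the aryl group on the ring nitrogen has so far shifted this assay by modest amounts without a consistent direction. For compound 4 a small rise toward a higher number is therefore expected, a 1.4-fold higher number from compound 1 to compound 4 (0.14 log units; within the scatter), though a step within the scatter would not surprise. The estimate for compound 4 is 2200 nM, expected to lie between 900 nM and 5400 nM.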

Compound 4, half-maximal inhibitory concentration: 3960 nM
Compound 4: the middle estimate sits 1.8-fold (0.26 log units) below what was measured; low and high end bracket the measured number.
By their numbers in this assay, from the lowest: compounds 1 and 3 (each within the scatter of the next); then compounds 2 and 4 (each within the scatter of the next).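

In this assay, pyridin-2-yl on the ring nitrogen gave a clear loss against both para-free... 

Correction, final text:

In this assay, pyridin-2-yl on the ring nitrogen moved the number up from both 4-methoxyphenyl (a 2.5-fold higher number from compound 1 to compound 4 (0.40 log units; beyond the scatter)) and 4-nitrophenyl (a 2.1-fold higher number from compound 3 to compound 4 (0.32 log units; beyond the scatter)). It matched 2-methylphenyl (a 1.0-fold higher number from compound 2 to compound 4 (0.00 log units; within the scatter)), so the four groups now form two sets, with compounds 1 and 3 in one and compounds 2 and 4 in the other. Nothing available explains this split. Going by these compounds, whether plain phenyl would join the first set or the second remains open. So does the outcome for pyridin-4-yl or benzyl on this nitrogen.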